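A few compounds are considered here, and "the series" means these few. Any claim that something is new, unique, unknown or untested is made for them only; others in the source may bear on it.

In a functional assay on H4 cells for agonist activity at growth hormone secretagogue receptor type 1 (Homo sapiens), read by FLIPR (on this read-out lower numbers stand for an effect already at smaller amounts and higher numbers for an effect only at larger amounts of compound), compound 1 `CC(C)(N)C(=O)N[C@H](COCc1ccccc1)c1nnnn1CCCc1ccccc1` gives 17 nM, and compound 2 `COC(=O)C(c1ccccc1)n1nnnc1[C@@H](COCc1ccccc1)NC(=O)C(C)(C)N` gives 20 nM; compound 3 `CC(C)(N)C(=O)N[C@H](COCc1ccccc1)c1nnn(Cc2ccccc2)n1` gives 1120 nM. Of these three numbers compound 2 holds the second highest, with compound 1 nearest and compound 3 furthest away. The step of a 1.2-fold higher number from compound 1 to compound 2 (0.07 log units; within the scatter) shows that swapping one group for another on the aromatic nitrogen left the number essentially where it was. Compound 4 `COC(=O)CCCn1nnnc1[C@@H](COCc1ccccc1)NC(=O)C(C)(C)N` takes the change (3-(methoxycarbonyl)propyl in place of methoxycarbonyl)(benzyl on an aromatic nitrogen), so that the group on that nitrogen no longer carries an aromatic ring but a short chain ending in an ester. Going by the values given here, compound 1 and compound 2 both carry an aromatic ring in that group and give almost the same number, while compound 3, which carries its ring on a different nitrogen of the same core, gives a far higher one; no step is recorded for that pair. Since nothing measured here removes the ring from this position, a somewhat higher number is expected for compound 4, namely 60 nM with a range from 15 nM to 250 nM, a step of a 3.0-fold higher number from compound 2 to compound 4 (0.48 log units; beyond the scatter) in this assay.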

Compound 4, half-maximal effective concentration: 55 nM
Compound 4: the middle estimate sits 1.1-fold (0.04 log units) above what was measured; low and high end bracket the measured number.
By their numbers in this assay, from the lowest: compounds 1 and 2 (each within the scatter of the next); then compound 4; then compound 3.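

The earlier compounds shown here all carry an aromatic ring in the group on this nitrogen, so they could not show what happens without one. In this assay compound 4 has no ring there and a smaller group, yet gives 55 nM and the change stays modest, with a 2.8-fold higher number from compound 2 to compound 4 (0.44 log units; beyond the scatter) while an ester remains in the group. Against the 3-phenylpropyl group, methoxycarbonyl in place of phenyl on the chain also gives only a modest change, a 3.2-fold higher number from compound 1 to compound 4 (0.51 log units; beyond the scatter) and so an aromatic ring at this position is not essential for an effect at low amounts of compound.

As far as these compounds go, how a carboxylic acid, an amine or a longer chain in place of the ester would shift the number remains open. Nothing given here explains these steps.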